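Phenyl to 3,4-dimethoxyphenyl: working notes on compound 3

A few compounds are considered here, and "the series" means these few. Any claim that something is new, unique, unknown or untested is made for them only; others in the source may bear on it.

In a functional assay on WM164 cells (Homo sapiens) for antiproliferative activity, read by sulforhodamine B assay, with a stated time of 48 h (a higher number here means a weaker inhibitor, a lower number a stronger inhibitor), compound 1 `CCCCCCCCCCCCCCNC(=O)[C@@H]1CSC(c2ccc(OC)c(OC)c2)N1` gives 800 nM. Among the measured compounds shown here, compound 2 `CCCCCCCCCCCCCCNC(=O)[C@@H]1CSC(c2ccccc2)=N1` gives > 50000 nM, which is a limit of the assay and not a number. the limit of > 50000 nM in this assay, at which 1 of the 2 values shown sits, is the only position known for compound 2, so no exact starting point exists for the next step.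

Compound 3 `CCCCCCCCCCCCCCNC(=O)[C@@H]1CSC(c2ccc(OC)c(OC)c2)=N1` follows from compound 2 by one change: 3,4-dimethoxyphenyl in place of phenyl on a carbon with a double bond to nitrogen. The expectation rests on compound 1, which also carries 3,4-dimethoxyphenyl and gives 800 nM. In this assay, the expected step of an at least 6.2-fold lower number from compound 2 to compound 3 (0.79 log units; beyond the scatter) runs toward stronger inhibition and beyond the scatter, though it remains uncertain in size. Compound 3 is estimated at 8000 nM, with an expected range of 1500 nM to 40000 nM.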

Compound 3, half-maximal inhibitory concentration: 42900 nM
Compound 3: the middle estimate sits 5.4-fold (0.73 log units) below what was measured, and the stated range ends below it.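

In this assay, the step on the carbon with a double bond to nitrogen reads an at least 1.1-fold lower number from compound 2 to compound 3 (0.06 log units; that floor lies within the scatter), so 3,4-dimethoxyphenyl in place of phenyl is not shown to give a real gain at this position. Both carrying 3,4-dimethoxyphenyl, compound 1 gives 800 nM and compound 3 gives 42900 nM, so this group does not by itself bring the number down to that of compound 1 when it sits on the core of compound 3. The true size of the step stays unknown because compound 2 is fixed only by a limit: the limit of > 50000 nM in this assay, at which 1 of the 3 values shown sits.

Open, on these data alone, is how phenyl would read on the core of compound 1. Also open, as far as these compounds go, is whether an amine or a carboxylic acid in place of 3,4-dimethoxyphenyl would move the number on either core.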